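A few compounds are considered here, and "the series" means these few. Any claim that something is new, unique, unknown or untested is made for them only; others in the source may bear on it.

Measured compounds in a functional assay on the whole organism (strain Swiss) with Mus musculus as the target, in the maximal electroshock model, with a stated time of 0.25 h, at a dose of 100 mg/kg by the intraperitoneal route; a lower number here means a weaker effect, a higher number a stronger effect of the compound at the dose given:

Compound 1, `CCC(C(=O)N1CCN(c2ccccc2F)CC1)N1C(=O)CCC1=O`, gives 0%.
Compound 2, `CC(C(=O)N1CCN(c2ccc(F)cc2)CC1)N1C(=O)CCC1=O`, gives 75%.
Compound 3, `CC(C(=O)N1CCN(c2ccccc2F)CC1)N1C(=O)CCC1=O`, gives 75%.

Compound 1 stands lowest of these three numbers; compound 2 and compound 3 both lie well beyond the scatter above it. The unmeasured compound 4, `CCC(C(=O)N1CCN(c2cccc(C)c2)CC1)N1C(=O)CCC1=O`, differs from compound 1 only at the aromatic group on the ring nitrogen: 3-methylphenyl in place of 2-fluorophenyl on an amine nitrogen in a ring. One measured step speaks to a change of this kind: swapping the fluorophenyl pattern between compound 2 and compound 3 gave no change at the digits printed from compound 2 to compound 3 (within the scatter), so the aryl group did not move the number there. The large step of a number 75 percentage points higher from compound 1 to compound 3 (beyond the scatter) instead belongs to the saturated chain, and compound 4 keeps the same chain as compound 1. The expectation for compound 4 is therefore a step of about a number 10 percentage points higher from compound 1 to compound 4 (within the scatter), that is, nothing beyond the scatter. Compound 4 is estimated at 10%, with a range from 0% to 40%.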

Compound 4, a percentage reported as activity, at one dose (the size of the read-out at that dose, not a potency): 50%
The estimate for compound 4 lay 40 percentage points below the measured number; measured number above the stated range.
By their numbers in this assay, from the lowest: compound 1; then compound 4; then compounds 2 and 3 (each within the scatter of the next).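

In this assay, the aromatic group on the ring nitrogen can matter a great deal: with the chain of compound 1 kept, 3-methylphenyl in place of 2-fluorophenyl gives a number 50 percentage points higher from compound 1 to compound 4 (beyond the scatter) and lifts the read-out well beyond the scatter. The earlier aryl swap, no change at the digits printed from compound 2 to compound 3 (within the scatter), was a different change made on the chain of compound 3, so its flat result did not carry over to this one. Nothing at hand explains the rise.

Going by these compounds, whether the rise follows the methyl group, its place on the phenyl ring or the departure of fluorine stays open, as does whether 3-methylphenyl would change anything on the chain of compound 3. An unsubstituted phenyl, 4-methylphenyl or 3-chlorophenyl group on the same nitrogen could help separate these readings.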